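The source may report more compounds than this note shows. Statements on the series, on what has been measured and on what is new or still open speak of the compounds shown alone.

Compound 3 `COc1ccccc1S(=O)(=O)Nc1ccc2oc(-c3ccccc3)nc2c1` stands in an assay on cells for inhibition of HSP60/HSP10 (Homo sapiens), with a stated time of 60 min (on this read-out higher numbers stand for weaker inhibition and lower numbers for stronger inhibition), only as a limit, since compound 3 gives > 100000 nM and no number. Its two neighbours fare no differently. Compound 1 `Cc1ccccc1S(=O)(=O)Nc1ccc2oc(-c3ccccc3)nc2c1` is also reported as a limit, giving > 100000 nM in this assay. Compound 2 `O=S(=O)(Nc1ccc2oc(-c3ccccc3)nc2c1)c1ccccc1Cl` likewise reaches only a limit, with > 100000 nM in this assay. The three share one feature: the limit of > 100000 nM in this assay, at which 3 of the 3 values shown sit. The steps among them, a step that the two limits leave unreadable from compound 1 to compound 2, a step that the two limits leave unreadable from compound 1 to compound 3 and a step that the two limits leave unreadable from compound 2 to compound 3, therefore cannot be sized, and none of them shows that any exchange of the group on that aromatic carbon moved the number.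

Compound 4 `O=S(=O)(Nc1ccc2oc(-c3ccccc3)nc2c1)c1ccccc1C(F)(F)F` differs from compound 3 by trifluoromethyl in place of methoxy on an aromatic carbon. The measured steps that bear on this change all sit at the limit, so they give no readable size in either direction. Compound 4 is therefore expected to remain at the limit as well, with the step from compound 3 to compound 4 estimated as a number no higher from compound 3 to compound 4 (the limit leaves the size open). For compound 4 the estimate in this assay is 100000 nM, with a range from 30000 nM to 300000 nM.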

Compound 4, half-maximal inhibitory concentration: > 100000 nM
Compound 4 ended at the assay's limit; the forecaster's own chance of this, stated with the estimate: 85%; the middle value lies on the limit itself.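

In this assay compound 4 gives > 100000 nM, which is a limit and not a number. Its steps from compound 1, compound 2 and compound 3 therefore cannot be read, and all four compounds share one result: the limit of > 100000 nM in this assay, at which 4 of the 4 values shown sit. The compounds shown leave open whether any group on that aromatic carbon changes the inhibition at all.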